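This account rests on a few compounds, and the source may have more. Where it says the series, first, only, none or still open, it means among the compounds named here.

Measured so far:
Compound 1, `CCCCCCCC/C=C\CCCCCCC[C@H](O)[C@@H](O)[C@H](O)C#CC#CCO`, gives 730 nM in a functional assay on HASMC cells (Homo sapiens) for inhibition, read by thymidine incorporation, with a stated time of 20 h; a lower number here means a stronger inhibitor, a higher number a weaker inhibitor.
Compound 2, `C#C/C=C\CCCCCCCCCC/C=C\CCCCCCC[C@H](O)[C@@H](O)[C@H](O)C#CC#CCO`, gives 720 nM in this assay.

Compound 2 holds the lowest of the two numbers, yet its gap to compound 1 lies within the scatter, so the two cannot be ordered. The unmeasured compound 3, `CCCCCCCCC/C=C\CCCCCCC[C@H](O)[C@@H](O)[C@H](O)C#CC#CCO`, arises from compound 2 by the change (a hydrogen atom in place of a group of 5 heavy atoms (5 carbon; no ring), on a saturated chain carbon, nine bonds along the chain from a double-bonded chain carbon). Within the data shown here, the only step that bears on it is a 1.0-fold lower number from compound 1 to compound 2 (0.01 log units; within the scatter), which lengthened the same chain without moving the number. Shortening it is therefore expected to leave the number where it stands, a step of no change at the digits printed from compound 2 to compound 3 (within the scatter). Compound 3 is estimated at 720 nM, within 400 nM to 1300 nM.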

Compound 3, half-maximal inhibitory concentration: 690 nM
Compound 3: middle estimate off by 1.0-fold (0.02 log units), on the high side, and the stated range covers the measured number.
By their numbers in this assay, from the lowest: compounds 3, 2 and 1 (each within the scatter of the next).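

In this assay a hydrogen atom in place of the group of 5 heavy atoms gives a 1.0-fold lower number from compound 2 to compound 3 (0.02 log units; within the scatter) and methyl in place of hydrogen gives a 1.1-fold lower number from compound 1 to compound 3 (0.02 log units; within the scatter) on a saturated chain carbon, eight bonds along the chain from a double-bonded chain carbon. Small and large changes on this chain thus both stay within the scatter, and the three compounds cannot be ordered. Nothing available explains this lack of change.

From the compounds shown here alone, whether a carboxylic acid or an amine on this chain, or a much shorter chain, would move the number remains open.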